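The source may report more compounds than this note shows. Statements on the series, on what has been measured and on what is new or still open speak of the compounds shown alone.

Measured compounds:
- compound 1, `O=C(O)Cn1c(=O)c(Oc2cc(O)cc(O)c2)nc2ccccc21`: 67.4%
- compound 2, `O=C(O)Cn1c(=O)c(Oc2ccc(O)cc2)nc2cc(F)ccc21`: 23.7%

In a physicochemical assay, read by spectrophotometry, with a stated time of 240 min, tested at 100 uM (on this read-out higher numbers stand for a stronger effect at the one concentration tested and lower numbers for a weaker effect), compound 2 gives 23.7%, the lower of the two numbers in hand. Within the data shown here, compound 1, a different structure in two places, gives 67.4% in this assay, and the gap between the two values lies beyond the scatter; no single step connects them, so only the two numbers themselves can be compared.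

Compound 3, `O=C(O)Cn1c(=O)c(Oc2cc(O)cc(O)c2)nc2cc(F)ccc21`, has not yet been measured in this assay. It differs from compound 2 in one place: 3,5-dihydroxyphenyl in place of 4-hydroxyphenyl on an oxygen on an aromatic ring. With this change compound 3 carries the same 3,5-dihydroxyphenyl as compound 1 on its core.

Because compound 1 gives 67.4% with this group present, compound 3 is expected to move upward from compound 2, by a step of about a number 31.3 percentage points higher from compound 2 to compound 3 (beyond the scatter) in this assay, beyond the scatter. The estimate for compound 3 in this assay is 55%, in a range from 30% to 78%.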

Compound 3, a percentage reported as activity, at one concentration (the size of the read-out at that concentration, not a potency): 25.4%
Beside the measured number, compound 3's estimate is 29.6 percentage points above it; the measured number lies below the stated range.
By their numbers in this assay, from the lowest: compounds 2 and 3 (each within the scatter of the next); then compound 1.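

In this assay, the change to 3,5-dihydroxyphenyl on an oxygen on an aromatic ring gives a number 1.7 percentage points higher from compound 2 to compound 3 (within the scatter), so with the fluoro present on the shared core, this group and 4-hydroxyphenyl cannot be told apart. Fluoro in place of hydrogen on an aromatic carbon, with 3,5-dihydroxyphenyl held constant, gives a number 42 percentage points lower from compound 1 to compound 3 (beyond the scatter), which places the large difference seen so far at the fluoro position rather than at the oxygen-linked ring. No measurement is at hand that explains this loss.

On these data alone, it remains open whether fluoro in place of hydrogen has a similar effect when 4-hydroxyphenyl is the group on the oxygen. The compounds shown also leave open whether chloro or methyl on that aromatic carbon would give a similar read-out.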